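This account rests on a few compounds, and the source may have more. Where it says the series, first, only, none or still open, it means among the compounds named here.

Working notes on the series. Compound 1 `COc1cc(C(=O)c2sc(Nc3ccccc3)nc2N)cc(OC)c1OC` is the reference point: in a functional assay on MOLT-4 cells (Homo sapiens) for antiproliferative activity, read by cell counting, with a stated time of 2 days (a higher number here means a weaker inhibitor, a lower number a stronger inhibitor), compound 1 gives 6 nM. Compound 3 `COc1ccc(Nc2nc(N)c(C(=O)c3cc(OC)c(OC)c(OC)c3)s2)cc1` differs from compound 1 in one place only, (methoxy in place of hydrogen on an aromatic carbon), and in this assay compound 3 gives 480 nM. Within the data shown here, the step of an 80-fold higher number from compound 1 to compound 3 (1.90 log units; beyond the scatter) is the only precedent so far for this change, and it is a large one.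

Compound 2 `COc1ccccc1C(=O)c1sc(Nc2ccccc2)nc1N` carries a different core from compound 1; the difference between the two cores is not broken down here. In this assay compound 2 gives 1300 nM, the highest number of the three measured, and its nearest neighbour on that scale is compound 3.

Compound 4 `COc1ccc(Nc2nc(N)c(C(=O)c3ccccc3OC)s2)cc1` has not yet been measured. It stands to compound 2 as compound 3 stands to compound 1: the change is methoxy in place of hydrogen on an aromatic carbon, the same change that was seen from compound 1 to compound 3. Among the measured compounds shown here, since the one measured instance of the change gave a large rise in number, the step of a 15-fold higher number from compound 2 to compound 4 (1.19 log units; beyond the scatter) is expected in the same direction as an 80-fold higher number from compound 1 to compound 3 (1.90 log units; beyond the scatter), though of less certain size because compound 2 already starts from 1300 nM on a core for which the change has not been tried. In this assay compound 4 is expected to give about 20000 nM. The estimate for compound 4 is taken to lie between 5000 nM and 100000 nM.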

Compound 4, half-maximal inhibitory concentration: 18 nM
Compound 4: the middle estimate sits 1100-fold (3.05 log units) above what was measured; measured number outside the range, below it.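

In this assay the change from phenyl to 4-methoxyphenyl, methoxy in place of hydrogen on an aromatic carbon para to a large group, gives a 72-fold lower number from compound 2 to compound 4 (1.86 log units; beyond the scatter) on the core of compound 2. So the direction of this change does not carry over from one core to the other, and the result for one core says little about the other in this series, as the two steps run opposite ways with a gap that cannot be put down to scatter: the same change on two cores in this assay, an 80-fold higher number (1.90 log units; beyond the scatter) from compound 1 to compound 3 and a 72-fold lower number (1.86 log units; beyond the scatter) from compound 2 to compound 4, 5800-fold (3.76 log units) apart, beyond the scatter of two such steps

These two pairs show that the outcome of the change depends on the core that carries it, but they give no rule for a third core, and they do not show which part of the difference between the two cores decides the direction, since that difference is not broken down here and nothing shown explains the reversal.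

The compounds shown leave open whether another group in the same place, such as an ethoxy group, an amine or a carboxylic acid, would also reverse its effect between these two cores. Also open, on these data alone, is how the change would behave on a core that carries only part of the difference between the core of compound 1 and the core of compound 2.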